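Carbamoyl in place of 1H-tetrazol-5-yl: what half-life to expect

A few compounds are considered here, and "the series" means these few. Any claim that something is new, unique, unknown or untested is made for them only; others in the source may bear on it.

Of the compounds shown here, two that share one core have been measured so far. In an ADME assay on microsomes from liver (Rattus norvegicus) for metabolic stability (a lower number here means that the compound disappears faster, a higher number that the compound lasts longer), compound 1 (`CC(C)C(c1ncco1)c1ccc(-c2ccc3cccc(F)c3c2)[nH]c1=O`) gives 0.0983 h, while compound 2 (`CC(C)C(Cc1nnn[nH]1)c1ccc(-c2ccc3cccc(F)c3c2)[nH]c1=O`) gives 2.08 h, the higher of the two numbers. Within the data shown here, the only measured step, a 21-fold higher number from compound 1 to compound 2 (1.33 log units; beyond the scatter), is large and came with (1H-tetrazol-5-yl)methyl in place of 1,3-oxazol-2-yl. It shows that a change at this part of the molecule can move the half-life a long way, but neither of its compounds carries carbamoyl.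

Compound 3 (`CC(C)C(CC(N)=O)c1ccc(-c2ccc3cccc(F)c3c2)[nH]c1=O`) has carbamoyl in place of 1H-tetrazol-5-yl on a saturated chain carbon, two bonds along the chain from an aromatic carbon. Among the measured compounds shown here, no measurement yet covers this swap, so any forecast is loose. For the measured compounds named here, compound 2 holds the top number so far at 2.08 h, which makes a fall more likely than a rise, and a much smaller one than the single step seen. The expected change is a 2.6-fold lower number from compound 2 to compound 3 (0.41 log units; beyond the scatter). For compound 3 the estimated half-life in this assay is 0.8 h, with an expected range from 0.25 h to 2.5 h.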

Compound 3, half-life: < 0.0667 h
Compound 3 was reported as a limit; the forecaster's own chance of this, stated with the estimate: 5%; middle value at least 11-fold (1.07 log units) from the limit.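

In this assay, the group on this chain carbon turns out to decide the outcome even when the chain stays the same, as the step with carbamoyl in place of 1H-tetrazol-5-yl shows: an at least 31-fold lower number from compound 2 to compound 3 (1.49 log units; beyond the scatter). Carbamoylmethyl and (1H-tetrazol-5-yl)methyl both hold the extra chain carbon that 1,3-oxazol-2-yl lacks, so that carbon alone does not go with the long half-life of compound 2, and the other step, an at least 1.4-fold lower number from compound 1 to compound 3 (0.16 log units; that floor lies within the scatter), has a floor within the usual scatter and does not set compound 3 clearly apart from compound 1. The number for compound 3 is a limit of the assay and not a measured half-life: the limit of < 0.0667 h in this assay, at which 1 of the 3 values shown sits.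

From the compounds shown here alone, how far the half-life of compound 3 really lies under that limit stays unknown, so the full size of the swap is open too. The compounds shown also leave open whether another group on the same chain carbon, such as a carboxylic acid or an amine, would stay near compound 2 or fall towards compound 3.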